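The compounds below may be only part of what the source reports. "The series", "measured", "known", "first", "only" and "open" are said of these compounds alone.

Working notes on the chalcone-amide series.

Compound 3 `COc1cccc(OC)c1C(=O)Nc1ccc(C(=O)/C=C/c2nc(C)c(C)nc2C)cc1` gives 3380 nM in a functional assay on HepG2 cells (Homo sapiens) for antiproliferative activity, read by CCK-8 assay, with a stated time of 72 h; on this read-out higher numbers stand for weaker inhibition and lower numbers for stronger inhibition. Among the three compounds measured, compound 3 holds the highest number, but its neighbours sit close: compound 2 `Cc1nc(C)c(/C=C/C(=O)c2ccc(NC(=O)c3ccc(F)cc3)cc2)nc1C` gives 2250 nM, and compound 1 `Cc1nc(C)c(/C=C/C(=O)c2ccc(NC(=O)c3ccccc3F)cc2)nc1C` gives 2040 nM. The step of a 1.7-fold higher number from compound 1 to compound 3 (0.22 log units; within the scatter) and the step of a 1.5-fold higher number from compound 2 to compound 3 (0.18 log units; within the scatter) both fall inside the scatter, as does a 1.1-fold higher number from compound 1 to compound 2 (0.04 log units; within the scatter), so no ordering among compounds 1, 2 and 3 can be read from these numbers.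

Compound 4 `COc1cc(OC)cc(C(=O)Nc2ccc(C(=O)/C=C/c3nc(C)c(C)nc3C)cc2)c1` has not yet been measured. Its difference from compound 3 is 3,5-dimethoxyphenyl in place of 2,6-dimethoxyphenyl on a carbonyl carbon. The three steps already seen all exchange one aryl group on this carbonyl carbon for another, and none moved the read-out beyond the scatter: fluorine in two different ring positions and a pair of methoxy groups give numbers that cannot be told apart. Within the data shown here, that is the only guidance; no step rearranging two methoxy groups on the same ring has been measured.

On this basis the expected step of a 1.0-fold higher number from compound 3 to compound 4 (0.00 log units; within the scatter) is no movement beyond the scatter. Compound 4 is therefore estimated to give 3400 nM in this assay, within a range of 1400 nM to 8000 nM.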

Compound 4, half-maximal inhibitory concentration: 11000 nM
Compound 4: the middle estimate sits 3.2-fold (0.51 log units) below what was measured; the measured number lies above the stated range.
By their numbers in this assay, from the lowest: compounds 1, 2 and 3 (each within the scatter of the next); then compound 4.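

Working from this assay, the exchange on a carbonyl carbon whose other neighbour is an amide-type nitrogen gives a 3.3-fold higher number from compound 3 to compound 4 (0.51 log units; beyond the scatter), the first step at this place to pass beyond the scatter. The group that leaves and the group that enters have the same atoms and the same counts, so the only difference is how the two methoxy groups are arranged on the ring: this arrangement can separate two compounds at a place where earlier aryl exchanges could not be told apart. The steps of a 4.9-fold higher number from compound 2 to compound 4 (0.69 log units; beyond the scatter) and a 5.4-fold higher number from compound 1 to compound 4 (0.73 log units; beyond the scatter) also pass beyond the scatter and leave compound 4 the weakest of the four, and nothing measured here accounts for the rise.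

On these data alone, whether the rise belongs to the 3,5-dimethoxyphenyl arrangement specifically or to any group with that arrangement stays open, as the series holds a single example of it. Equally open, as far as these compounds go, is how a phenyl ring carrying just one methoxy group, or an amine or a carboxylic acid on that ring, would read in this assay.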